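Chloro for hydrogen on the shared core: series notes

The source may hold more compounds than are shown below. What is called first, only, known or untested is meant among the compounds shown, and "the series" means these compounds.

Measured so far:
compound 1 `O=S(=O)(c1cnc2ccccc2c1)n1cc(C2=CCNCC2)c2ccccc21` — 13 nM
compound 2 `O=S(=O)(c1ccc2cccnc2c1)n1cc(C2=CCNCC2)c2ccccc21` — 7 nM
compound 3 `O=S(=O)(c1cnc2ccccc2c1)n1cc(C2=CCNCC2)c2cc(Cl)ccc21` — 11 nM

In an assay on HEK293 cells for displacement of a labelled ligand from 5-hydroxytryptamine receptor 6 (Homo sapiens), read by scintillation counting (on this read-out lower numbers stand for stronger inhibition and higher numbers for weaker inhibition), compound 1 gives 13 nM, compound 2 gives 7 nM and compound 3 gives 11 nM. Compound 2 carries the lowest of the three numbers, but its gaps to compound 3 and to compound 1 both lie within the usual scatter, so no order among the three is claimed.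

Compound 1 and compound 3 differ in one place only: chloro in place of hydrogen on an aromatic carbon. That change gave a 1.2-fold lower number from compound 1 to compound 3 (0.07 log units; within the scatter), a step within the scatter. Compound 1 and compound 2 have the same atoms joined differently; the difference between the two cores is not broken down here, and the two values simply sit close to one another.

Compound 4 `O=S(=O)(c1ccc2cccnc2c1)n1cc(C2=CCNCC2)c2cc(Cl)ccc21` is not yet measured in this assay. It differs from compound 2 by chloro in place of hydrogen on an aromatic carbon. The place is described in the same words as for the change from compound 1 to compound 3, so this is the same change carried onto the core of compound 2, and it occurs twice among the four compounds.

For compound 4 the expected step is a 1.2-fold lower number from compound 2 to compound 4 (0.07 log units; within the scatter), which rests on a 1.2-fold lower number from compound 1 to compound 3 (0.07 log units; within the scatter) having stayed within the scatter on the other core. Compound 4 is therefore estimated at 6 nM in this assay, with the likely range from 3 nM to 14 nM; a single measurement cannot separate it from compound 2.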

Compound 4, inhibition constant: 9 nM
Estimate against measurement, compound 4: 1.5-fold (0.18 log units) below; low and high end bracket the measured number.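

In this assay, chloro in place of hydrogen on an aromatic carbon gave a 1.3-fold higher number from compound 2 to compound 4 (0.11 log units; within the scatter), so on the core of compound 2 this change again leaves the number within the scatter. Set beside the earlier step, the change reads the same on both cores, and the opposite signs of the two steps mark no real difference between them: the same change on two cores in this assay, a 1.2-fold lower number (0.07 log units; within the scatter) from compound 1 to compound 3 and a 1.3-fold higher number (0.11 log units; within the scatter) from compound 2 to compound 4, 1.5-fold (0.18 log units) apart, within the scatter of two such steps

Within the data shown here, this shows only that a step too small to read on one core stayed too small to read on the other; it does not show that chloro has any effect of its own on either core, and with just two pairs it gives no general rule for the series.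

The compounds shown hold only hydrogen or chloro at this place, so it stays open what fluoro, methoxy, trifluoromethyl, nitrile or a carboxylic acid would do there. Also open, from the compounds shown here alone, is whether a step beyond the scatter at this place would carry from the core of compound 1 to the core of compound 2 as closely as this small one did.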